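This account rests on a few compounds, and the source may have more. Where it says the series, first, only, none or still open, it means among the compounds named here.

Of the compounds shown here, three with a shared core have been tested in a functional assay on the whole organism with Rattus norvegicus as the target; a lower number here means that less compound is needed, a higher number that more compound is needed for the effect. Compound 1 `CS(=O)(=O)c1ccc(-c2[nH]ccc2-c2ccc(F)cc2)cc1` reaches only a limit in this assay, > 100 mg/kg. Compound 2 `CS(=O)(=O)c1ccc(-c2[nH]c(Br)cc2-c2ccc(F)cc2)cc1` gives 1.05 mg/kg, and compound 3 `CS(=O)(=O)c1ccc(-c2[nH]c(C(=O)C(F)(F)F)cc2-c2ccc(F)cc2)cc1` gives 19.4 mg/kg. Compound 2 thus stands lowest of the two numbers; the nearest measured step is an 18-fold higher number from compound 2 to compound 3 (1.27 log units; beyond the scatter). The other steps were an at least 95-fold lower number from compound 1 to compound 2 (1.97 log units; beyond the scatter) and an at least 5.1-fold lower number from compound 1 to compound 3 (0.71 log units; beyond the scatter). Compound 4 `Cc1ccc(S(=O)(=O)n2c(Br)cc(-c3ccc(F)cc3)c2-c2ccc(S(C)(=O)=O)cc2)cc1` differs from compound 2 by (4-methylphenyl)sulfonyl in place of hydrogen on an aromatic nitrogen. Every measured step changes a substituent on an aromatic carbon, none the aromatic nitrogen, so they offer no direct guide. Compound 4 is therefore expected to show a 2.4-fold higher number from compound 2 to compound 4 (0.38 log units; beyond the scatter), a modest rise at most. The estimate for compound 4 is 2.5 mg/kg, within 0.7 mg/kg to 15 mg/kg.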

Compound 4, dose for half-maximal effect: > 9 mg/kg
Compound 4 ended at the assay's limit; the forecaster's own chance of this, stated with the estimate: 10%; at least 3.6-fold (0.55 log units) between middle value and limit.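

The first change shown on the aromatic nitrogen is not neutral in this assay: (4-methylphenyl)sulfonyl in place of hydrogen gives an at least 8.5-fold higher number from compound 2 to compound 4 (0.93 log units; beyond the scatter). With bromo on the ring, the free hydrogen on that nitrogen therefore goes with the lower number. Compound 4 stands at a limit of the assay, so the full size of this step is unknown: the limit of > 9 mg/kg in this assay, at which 1 of the 4 values shown sits.

Going by these compounds, whether a methyl or acetyl group on that nitrogen would behave like the hydrogen or like (4-methylphenyl)sulfonyl remains open. So does whether the same change would have a similar effect with (trifluoromethyl)carbonyl in place of bromo.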